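The compounds below may be only part of what the source reports. "The series", "measured", "known", "first", "only" and "open" are said of these compounds alone.

Notes on the chain series. Compound 1 (`CCCCCCCCn1cc(COC[C@@H]2OC[C@H](N)[C@@H]2O)nn1`) and compound 2 (`CCCCCCCCCn1cc(COC[C@@H]2OC[C@H](N)[C@@H]2O)nn1`) share a core and differ only in the chain on the aromatic nitrogen. Among the measured compounds shown here, in a functional assay on EC9706 cells (Homo sapiens) for antiproliferative activity, read by MTT assay, with a stated time of 48 h (on this read-out lower numbers stand for stronger inhibition and higher numbers for weaker inhibition), compound 1 gives 44300 nM and compound 2 gives 20100 nM, the lower of the two numbers so far. Compound 3 (`CCCCCCCCCCn1cc(COC[C@@H]2OC[C@H](N)[C@@H]2O)nn1`) is not yet measured, and its difference from compound 2 is methyl in place of hydrogen on a saturated chain carbon, nine bonds along the chain from an aromatic nitrogen. For the measured compounds named here, only one measured step bears on this change, the same replacement of hydrogen by methyl: a 2.2-fold lower number from compound 1 to compound 2 (0.34 log units; beyond the scatter), a modest step. A single step does not establish a trend, so the chain may stop following it. A further modest step to a lower number in this assay is still expected. The estimate amounts to an expected 2.0-fold lower number from compound 2 to compound 3 (0.30 log units; within the scatter). For compound 3 the expected value is 10000 nM, with an estimated range of 4000 nM to 23000 nM.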

Compound 3, half-maximal inhibitory concentration: 15600 nM
Estimate against measurement, compound 3: 1.6-fold (0.19 log units) below; the measured number falls inside the stated range.
By their numbers in this assay, from the lowest: compounds 3 and 2 (each within the scatter of the next); then compound 1.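

In this assay, methyl in place of hydrogen on a saturated chain carbon, nine bonds along the chain from an aromatic nitrogen, gives a 1.3-fold lower number from compound 2 to compound 3 (0.11 log units; within the scatter) and so, unlike a 2.2-fold lower number from compound 1 to compound 2 (0.34 log units; beyond the scatter) at the position one bond nearer, does not clear the scatter. Compound 2 and compound 3 therefore cannot be told apart on this read-out, while the two chain extensions taken together give a 2.8-fold lower number from compound 1 to compound 3 (0.45 log units; beyond the scatter) and do separate compound 3 from compound 1. No available data explain this chain-length behaviour.

The compounds shown leave open whether a longer chain would bring a step beyond the scatter or leave the numbers level. They also leave open how an amine or a carboxylic acid in place of this methyl would read.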